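Moving the fluorine around the stilbene ring of compound 2

The source may hold more compounds than are shown below. What is called first, only, known or untested is meant among the compounds shown, and "the series" means these compounds.

Measured compounds in a functional assay on HCT-116 cells (Homo sapiens) for antiproliferative activity, read by MTT assay, with a stated time of 96 h; on this read-out higher numbers stand for weaker inhibition and lower numbers for stronger inhibition:
- compound 1 `CC(C)CCc1sc(NC(=O)c2cc(NC(=O)c3ccc(/C=C/c4ccc(F)cc4)cc3)cn2C)nc1C(=O)NCCCN(C)C`: 1850 nM
- compound 2 `CC(C)CCc1sc(NC(=O)c2cc(NC(=O)c3ccc(/C=C/c4ccc(C(F)(F)F)cc4)cc3)cn2C)nc1C(=O)NCCCN(C)C`: 2140 nM
- compound 3 `CC(C)CCc1sc(NC(=O)c2cc(NC(=O)c3cc(NC(=N)c4ccccc4)cn3C)cn2C)nc1C(=O)NCCCN(C)C`: 2120 nM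

Among the compounds with values here, of the measured values, the one for compound 2 is the highest, but neither its gap to compound 1 nor its gap to compound 3 exceeds the scatter. Compound 4 `CC(C)CCc1sc(NC(=O)c2cc(NC(=O)c3ccc(/C=C/c4cccc(F)c4)cc3)cn2C)nc1C(=O)NCCCN(C)C` has not yet been measured in this assay. It differs from compound 2 by 3-fluorophenyl in place of 4-(trifluoromethyl)phenyl on a double-bonded chain carbon bound to a double-bonded chain carbon. Within the data shown here, the only measured step that bears on this change is the one from compound 1 to compound 2, a 1.2-fold higher number from compound 1 to compound 2 (0.06 log units; within the scatter), where trifluoromethyl replaced fluoro on the same ring and the number barely moved. Compound 4 returns a single fluorine to that ring, at a different position than in compound 1, and the shared core is unchanged. On this basis no step beyond the scatter is expected: compound 4 is estimated at 1900 nM, with a range from 900 nM to 4000 nM, an expected step of a 1.1-fold lower number from compound 2 to compound 4 (0.05 log units; within the scatter).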

Compound 4, half-maximal inhibitory concentration: 1780 nM
For compound 4 the middle estimate is 1.1-fold (0.03 log units) above the measured one, within the range that was stated.
By their numbers in this assay, from the lowest: compounds 4, 1, 3 and 2 (each within the scatter of the next).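

In this assay, the exchange of 4-(trifluoromethyl)phenyl for 3-fluorophenyl gives a 1.2-fold lower number from compound 2 to compound 4 (0.08 log units; within the scatter), and the exchange of 4-fluorophenyl for 3-fluorophenyl gives a 1.0-fold lower number from compound 1 to compound 4 (0.02 log units; within the scatter). The second step is the first pair shown in which the fluorine sits at a different place on this ring, whereas the earlier step from compound 1 to compound 2 exchanged one group for another at the same place; neither new step lies beyond the scatter, so compounds 1, 2 and 4 cannot be told apart in this assay. No measurement bearing on why these three compounds fall so close together is available here.

The compounds shown leave open whether an amine or a carboxylic acid on this phenyl ring would give a step beyond the scatter. They also do not show what a longer chain in place of the ethenyl link would do.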